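This account rests on a few compounds, and the source may have more. Where it says the series, first, only, none or still open, it means among the compounds named here.

Measured so far:
compound 1 `CC1=C(/C=C/C(=O)/C=C/c2ccc(Br)cc2)C(C)(C)CCC1`, 88800 nM
compound 2 `CC1=C(/C=C/C(=O)/C=C/c2ccc(F)cc2)C(C)(C)CCC1`, 32200 nM
compound 3 `CC1=C(/C=C/C(=O)/C=C/c2ccccc2Br)C(C)(C)CCC1`, 57900 nM

All three share one core and differ only in the aryl group on the double-bonded chain carbon. In a functional assay on HeLa cells (Homo sapiens) for cytotoxicity, read by sulforhodamine B assay, with a stated time of 48 h (on this read-out higher numbers stand for weaker inhibition and lower numbers for stronger inhibition), compound 1 gives 88800 nM, while compound 2 gives 32200 nM. The difference between them is fluoro in place of bromo on an aromatic carbon, and it made a 2.8-fold lower number from compound 1 to compound 2 (0.44 log units; beyond the scatter). Compound 3 gives 57900 nM in this assay; its core differs from that of compound 1 by 2-bromophenyl in place of 4-bromophenyl on a double-bonded chain carbon bound to a double-bonded chain carbon, with a 1.5-fold lower number from compound 1 to compound 3 (0.19 log units; within the scatter). Between compound 2 and compound 3 the record shows a 1.8-fold higher number from compound 2 to compound 3 (0.25 log units; within the scatter), so compound 2 and compound 3 cannot be ordered against each other.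

Compound 4 `CC1=C(/C=C/C(=O)/C=C/c2ccccc2F)C(C)(C)CCC1` has not been measured. It differs from compound 3 by fluoro in place of bromo on an aromatic carbon. Going by the values given here, this is the same kind of change as the one from compound 1 to compound 2, but not the same: there the fluoro sits on an aromatic carbon para to a large group, here it sits on an aromatic carbon ortho to a large group. Among the compounds with values here, only one instance of this change has been measured, so the expectation rests on a single step.

In this assay compound 4 is expected to show a 2.3-fold lower number from compound 3 to compound 4 (0.36 log units; beyond the scatter), a step of about the size seen from compound 1 to compound 2 because of a 2.8-fold lower number from compound 1 to compound 2 (0.44 log units; beyond the scatter). The estimate for compound 4 is 25000 nM, with a range from 10000 nM to 60000 nM.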

Compound 4, half-maximal inhibitory concentration: 41900 nM
Compound 4: middle estimate off by 1.7-fold (0.22 log units), on the low side; low and high end bracket the measured number.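

The change from 2-bromophenyl to 2-fluorophenyl gives, in this assay, a 1.4-fold lower number from compound 3 to compound 4 (0.14 log units; within the scatter), and the two instances of fluoro in place of bromo cannot be told apart: the same change on two cores in this assay, a 2.8-fold lower number (0.44 log units; beyond the scatter) from compound 1 to compound 2 and a 1.4-fold lower number (0.14 log units; within the scatter) from compound 3 to compound 4, 2.0-fold (0.30 log units) apart, within the scatter of two such steps This agrees with the change carrying from one core to the other, but does not establish it: only the earlier step lies beyond the scatter, the new step on its own separates nothing, and two steps are too few to fix a size for the change. The other new readings are a 1.3-fold higher number from compound 2 to compound 4 (0.11 log units; within the scatter), which leaves the two fluoro compounds unordered, and a 2.1-fold lower number from compound 1 to compound 4 (0.33 log units; beyond the scatter), a step that replaces the halogen and moves it in one go, so it cannot be assigned to either part of that difference.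

The compounds shown leave open whether the step holds for other replacements on the aromatic ring, such as a chloro, methoxy or amine group, since all four compounds carry only bromo or fluoro. Also open, going by these compounds, is whether it survives a change elsewhere in the shared core, such as a longer chain between the carbonyl and the aromatic ring.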